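Moving the Pyridine Nitrogen in a Dopamine Transporter Series

The source may hold more compounds than are shown below. What is called first, only, known or untested is meant among the compounds shown, and "the series" means these compounds.

In an assay on striatum for inhibition of sodium-dependent dopamine transporter (Rattus norvegicus) (on this read-out lower numbers stand for stronger inhibition and higher numbers for weaker inhibition), compound 2 `c1ccc(C(c2ccccc2)[C@@H]2CC[C@H](NCc3ccncc3)CO2)cc1` gives 28.3 nM, and compound 1 `Oc1cccc(CN[C@H]2CC[C@@H](C(c3ccccc3)c3ccccc3)OC2)c1` gives 31.3 nM; these two numbers, the only ones measured, lie within the scatter of each other. Compound 3 `c1ccc(C(c2ccccc2)[C@@H]2CC[C@H](NCc3ccccn3)CO2)cc1` differs from compound 2 by pyridin-2-yl in place of pyridin-4-yl on a saturated chain carbon bound to an amine nitrogen. Going by the values given here, the one measured step at that place, a 1.1-fold lower number from compound 1 to compound 2 (0.04 log units; within the scatter), was a different ring swap and stayed within the scatter, so for compound 3 no change beyond the scatter is expected in this assay. The estimate for compound 3 is 30 nM, between 10 nM and 90 nM. The expected step is a 1.1-fold higher number from compound 2 to compound 3 (0.03 log units; within the scatter).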

Compound 3, inhibition constant: 209 nM
Estimate against measurement, compound 3: 7.0-fold (0.84 log units) below; measured number above the stated range.
By their numbers in this assay, from the lowest: compounds 2 and 1 (each within the scatter of the next); then compound 3.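

In this assay, the placement of the ring nitrogen matters for the group on a saturated chain carbon bound to an amine nitrogen: pyridin-2-yl in place of pyridin-4-yl, with the same atoms joined differently, gives a 7.4-fold higher number from compound 2 to compound 3 (0.87 log units; beyond the scatter). Pyridin-2-yl in place of 3-hydroxyphenyl gives a 6.7-fold higher number from compound 1 to compound 3 (0.82 log units; beyond the scatter), so not every ring swap here stays within the scatter, and inhibition is weaker with pyridin-2-yl. On these data alone, whether pyridin-3-yl would stand with pyridin-4-yl or with pyridin-2-yl remains open. Nothing available here gives a reason for the weaker inhibition.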